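From pyridin-3-yl to pyrimidin-4-yl on an amide-type nitrogen

The source may hold more compounds than are shown below. What is called first, only, known or untested is meant among the compounds shown, and "the series" means these compounds.

Measured in an ADME assay on LLC-MK2 cells (Macaca mulatta) for cytotoxicity, read by spectrophotometry and crystal violet staining, with a stated time of 4 days; a higher number here means that more compound is tolerated, a lower number that less compound is tolerated:
Compound 1 `CC(C)n1ncc2c(C(=O)Nc3ccccc3S(N)(=O)=O)cc(-c3cccs3)nc21` gives 25000 nM
Compound 2 `CC(C)n1ncc2c(C(=O)Nc3cccnc3)cc(-c3cccs3)nc21` gives > 200000 nM (a limit, not a number)

Compound 2 has only a limit here and stands at the limit of > 200000 nM in this assay, at which 1 of the 2 values shown sits. Compound 3 `CC(C)n1ncc2c(C(=O)Nc3ccncn3)cc(-c3cccs3)nc21` carries pyrimidin-4-yl in place of pyridin-3-yl on an amide-type nitrogen, and the change is pyrimidin-4-yl in place of pyridin-3-yl on an amide-type nitrogen. Going by the values given here, one measured step bears on this place: an at least 8.0-fold higher number from compound 1 to compound 2 (0.90 log units; beyond the scatter). That step lies beyond the scatter, but it removed 2-sulfamoylphenyl, a group that neither compound 2 nor compound 3 carries. It therefore gives no size for an exchange of one six-membered aromatic ring for another, and no step beyond the scatter is expected in either direction. The estimate for compound 3 in this assay is an expected value of 200000 nM, with an expected range from 80000 nM to 400000 nM. This corresponds to an expected step of a number no higher from compound 2 to compound 3 (the limit leaves the size open).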

Compound 3, half-maximal cytotoxic concentration: 50000 nM
The estimate for compound 3 lay 4.0-fold (0.60 log units) above the measured number; measured number outside the range, below it.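

In this assay, the exchange of one six-membered aromatic ring for another on the amide-type nitrogen proves able to move the number: pyrimidin-4-yl in place of pyridin-3-yl gives an at least 4.0-fold lower number from compound 2 to compound 3 (0.60 log units; beyond the scatter). The value of compound 2 is a limit and not a number: the limit of > 200000 nM in this assay, at which 1 of the 3 values shown sits. Losing 2-sulfamoylphenyl is also not enough on its own to reach that limit, since pyrimidin-4-yl in its place gives a 2.0-fold higher number from compound 1 to compound 3 (0.30 log units; within the scatter).

The true size of the step from pyridin-3-yl to pyrimidin-4-yl remains open, and the compounds shown give no reason for it. On these data alone, whether pyridin-4-yl or an unsubstituted phenyl ring on this nitrogen would stand with compound 2 or with compound 3 also remains open.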